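A Methoxy Group Added to Compound 2

The source may report more compounds than this note shows. Statements on the series, on what has been measured and on what is new or still open speak of the compounds shown alone.

Compound 1 (`C/C1=C\CC[C@@]2(C)O[C@@H]2[C@H]2OC(=O)[C@@H](CN(C)CCN(C)C)[C@@H]2C[C@H]1O`) and compound 2 (`C/C1=C\CC[C@@]2(C)O[C@@H]2[C@H]2OC(=O)[C@@H](CN3CCN(c4ccccc4)CC3)[C@@H]2C[C@H]1O`) share a core and differ in the side chain attached to it. In a functional assay on SK-MEL-28 cells (Homo sapiens) for inhibition, read by MTT assay, with a stated time of 72 h (on this read-out higher numbers stand for weaker inhibition and lower numbers for stronger inhibition), compound 1 gives 19000 nM and compound 2 gives 19000 nM so the two stand level within the scatter. Compound 3 (`COc1ccc(N2CCN(C[C@@H]3C(=O)O[C@H]4[C@H]3C[C@@H](O)/C(C)=C/CC[C@@]3(C)O[C@H]43)CC2)cc1`) follows from compound 2 by a change from phenyl to 4-methoxyphenyl (methoxy in place of hydrogen on an aromatic carbon) with methoxy in place of hydrogen on an aromatic carbon, para to a large group. Going by the values given here, no measured pair of compounds differs in one place, so the data hold no direct precedent for this change. In this assay no step beyond the scatter is expected, and the estimated step is a 1.1-fold lower number from compound 2 to compound 3 (0.05 log units; within the scatter) in this read-out. Compound 3 is estimated at 17000 nM with an expected range from 7000 nM to 40000 nM in this read-out.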

Compound 3, half-maximal inhibitory concentration: 25000 nM
Compound 3: middle estimate off by 1.5-fold (0.17 log units), on the low side; measured number inside the range.
By their numbers in this assay, from the lowest: compounds 1, 2 and 3 (each within the scatter of the next).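

In this assay the replacement of hydrogen by methoxy on the aromatic carbon, para to a large group, gives a 1.3-fold higher number from compound 2 to compound 3 (0.12 log units; within the scatter) and so leaves the read-out unmoved within the scatter. Going by these compounds alone, compounds 1 and 2 differ across the whole side chain, so only this pair isolates a single place on the aromatic ring, and at that place the added methoxy group brings no step beyond the scatter. Nothing in the data offers an explanation for this result.

On these data alone, whether an amine or a carboxylic acid at this place would move the number beyond the scatter stays open, as does the effect of methoxy on another carbon of the ring. With all three compounds level within the scatter, the compounds shown also do not tell which part of the side chain, if any, governs the read-out.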